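The compounds below may be only part of what the source reports. "The series", "measured", "known", "first", "only" and "open" are said of these compounds alone.

Measured compounds:
- compound 1 `CC[C@@H]1/C=C(\C)C[C@H](C)C[C@H](OC)[C@H]2O[C@@](O)(C(=O)C(=O)N3CCCC[C@H]3C(=O)O[C@H](/C(C)=C/[C@@H]3CC[C@@H](Oc4ccc(C(F)(F)F)cc4)[C@H](OC)C3)[C@H](C)[C@@H](O)CC1=O)[C@H](C)C[C@@H]2OC`, which in a functional assay on cells for inhibition, with Murine T-cell line (Mus musculus) as the target (on this read-out higher numbers stand for weaker inhibition and lower numbers for stronger inhibition), gives 35.8 nM
- compound 2 `CC[C@@H]1/C=C(\C)C[C@H](C)C[C@H](OC)[C@H]2O[C@@](O)(C(=O)C(=O)N3CCCC[C@H]3C(=O)O[C@H](/C(C)=C/[C@@H]3CC[C@@H](Oc4ccc(O)cc4)[C@H](OC)C3)[C@H](C)[C@@H](O)CC1=O)[C@H](C)C[C@@H]2OC`, which in this assay gives 0.8 nM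
- compound 3 `CC[C@@H]1/C=C(\C)C[C@H](C)C[C@H](OC)[C@H]2O[C@@](O)(C(=O)C(=O)N3CCCC[C@H]3C(=O)O[C@H](/C(C)=C/[C@@H]3CC[C@@H](Oc4ccc(OC)cc4)[C@H](OC)C3)[C@H](C)[C@@H](O)CC1=O)[C@H](C)C[C@@H]2OC`, which in this assay gives 1.4 nM

Compound 3 stands second among the three numbers: it differs from compound 2 by a step within the scatter, a 1.8-fold higher number from compound 2 to compound 3 (0.24 log units; within the scatter), while compound 1 lies far from both, as a 26-fold lower number from compound 1 to compound 3 (1.41 log units; beyond the scatter) and a 45-fold lower number from compound 1 to compound 2 (1.65 log units; beyond the scatter) show. Compound 4 `CC[C@@H]1/C=C(\C)C[C@H](C)C[C@H](OC)[C@H]2O[C@@](O)(C(=O)C(=O)N3CCCC[C@H]3C(=O)O[C@H](/C(C)=C/[C@@H]3CC[C@@H](Oc4ccc(SC)cc4)[C@H](OC)C3)[C@H](C)[C@@H](O)CC1=O)[C@H](C)C[C@@H]2OC` carries the change (methylsulfanyl in place of methoxy on an aromatic carbon). For the measured compounds named here, no measured step repeats this change. Going by the values given here, the one step between the two small groups, a 1.8-fold higher number from compound 2 to compound 3 (0.24 log units; within the scatter), was within the scatter, whereas the trifluoromethyl steps were large. Compound 4 is therefore expected to lie near compound 3, with the step of a 1.8-fold higher number from compound 3 to compound 4 (0.25 log units; within the scatter) estimated small. Compound 4 is estimated at 2.5 nM, between 0.8 nM and 8 nM.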

Compound 4, half-maximal inhibitory concentration: 2.6 nM
The estimate for compound 4 lay 1.0-fold (0.02 log units) below the measured number; measured number inside the range.
By their numbers in this assay, from the lowest: compounds 2, 3 and 4 (each within the scatter of the next, the first and the last beyond it); then compound 1.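

In this assay, sulfur can replace oxygen in this group at this position with a step that stays within the scatter, a 1.9-fold higher number from compound 3 to compound 4 (0.27 log units; within the scatter), and methylsulfanyl remains well apart from trifluoromethyl, a 14-fold lower number from compound 1 to compound 4 (1.14 log units; beyond the scatter). Hydroxy and methoxy could not be told apart, yet hydroxy and methylsulfanyl can, with a modest step, a 3.3-fold higher number from compound 2 to compound 4 (0.51 log units; beyond the scatter), the first beyond the scatter among these three groups. No measurement given here accounts for these steps.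

On these data alone, whether an amine, a carboxylic acid or a longer chain such as ethylsulfanyl at this position would stay with these three groups or fall nearer trifluoromethyl remains open.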